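Tail aryl variation in the carbamate series

The source may hold more compounds than are shown below. What is called first, only, known or untested is meant among the compounds shown, and "the series" means these compounds.

Two compounds of this series carry a measurement in a functional assay on A549 cells (Homo sapiens) for cytotoxicity; a lower number here means a stronger inhibitor, a higher number a weaker inhibitor. Compound 1 `C=C/C=C\[C@H](C)[C@H](OC(N)=O)[C@@H](C)[C@H](O)[C@@H](C)C/C(C)=C\[C@H](C)[C@@H](O)[C@@H](C)/C=C\CCc1ccc(Oc2ccccc2)cc1` has one aryl tail on the shared core; in this assay compound 1 gives 10000 nM. Compound 2 `C=C/C=C\[C@H](C)[C@H](OC(N)=O)[C@@H](C)[C@H](O)[C@@H](C)C/C(C)=C\[C@H](C)[C@@H](O)[C@@H](C)/C=C\CCc1ccc(C)c(O)c1` carries a 3-hydroxy-4-methylphenyl tail in its place; in this assay compound 2 gives 4000 nM, the lower of the two numbers, and the gap to compound 1 lies beyond the scatter. Among the measured compounds shown here, no measured pair differs in a single place, so no step size is known directly.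

Compound 3 `C=C/C=C\[C@H](C)[C@H](OC(N)=O)[C@@H](C)[C@H](O)[C@@H](C)C/C(C)=C\[C@H](C)[C@@H](O)[C@@H](C)/C=C\CCc1cccc(O)c1` is the next point. It differs from compound 2 as follows: hydrogen in place of methyl on an aromatic carbon. The hydroxy group and the rest of the core are kept; only the methyl on the aromatic carbon is removed. Nothing measured bears on a methyl at this place, so the step in this assay is expected to be small, with no direction beyond the scatter favoured. The estimated step of a 1.3-fold higher number from compound 2 to compound 3 (0.10 log units; within the scatter) is accordingly set near none. Compound 3 is expected to give about 5000 nM in this assay, within 2000 nM to 15000 nM.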

Compound 3, half-maximal inhibitory concentration: 190 nM
For compound 3 the middle estimate is 26-fold (1.42 log units) above the measured one, outside the stated range (below it).
By their numbers in this assay, from the lowest: compound 3; then compound 2; then compound 1.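

Replacing the methyl with hydrogen, which turns the 3-hydroxy-4-methylphenyl tail into the 3-hydroxyphenyl tail, gives a 21-fold lower number from compound 2 to compound 3 (1.32 log units; beyond the scatter) in this assay. Among the compounds shown here, this pair is the first to differ in a single place, and it shows that the aromatic carbon ortho to the hydroxy group and para to the large group is not a neutral site in this tail: the loss of one carbon atom alone separates the two compounds by a large step. Nothing at hand accounts for the size of this step.

The compounds shown leave open whether the step holds without the hydroxy group, which a methoxy group or an amine in its place would test, and whether other groups on the same aromatic carbon, such as fluorine, ethyl or methoxy, fall with methyl or with hydrogen. Compound 1 differs from compound 2 and from compound 3 in more than one place, so its steps to them cannot be read, and the contribution of its tail stays unresolved.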